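The source may hold more compounds than are shown below. What is called first, only, known or untested is meant among the compounds shown, and "the series" means these compounds.

Of the compounds shown here, three have been measured in a functional assay on MCF7 cells (Homo sapiens) for antiproliferative activity, read by MTT assay, with a stated time of 72 h; on this read-out higher numbers stand for weaker inhibition and lower numbers for stronger inhibition. Compound 1 `Cc1c(C=C(CO)CO)n(C)c(=O)[nH]c1=O` returns only a limit of the assay, > 100000 nM. Compound 2 `COc1nc(CC(O)(COCc2ccccc2)COCc2ccccc2)c(C)c(OC)n1` gives a measured number in this assay, 4220 nM. Compound 3 `COc1nc(CC(O)(COC(C)=O)COC(C)=O)c(C)c(OC)n1` likewise returns a limit rather than a number, and compound 3 shows > 100000 nM. Compound 3 therefore stands at the limit of > 100000 nM in this assay, at which 2 of the 3 values shown sit, and among the three measured compounds only compound 2 has a numerical read-out.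

Compound 4 `COc1nc(CC(F)(COC(C)=O)COC(C)=O)c(C)c(OC)n1` has not yet been measured. It differs from compound 3 by fluoro in place of hydroxy on a saturated chain carbon bound to three saturated chain carbons. Among the compounds with values here, no pair of measured compounds that differs in a single place is available, so the size of this kind of step has no precedent. Starting from a limit, a change no larger than the scatter would leave compound 4 at the limit as well. The expected step is a step that the limit leaves unreadable from compound 3 to compound 4, which is none beyond the scatter. Compound 4 is expected to give 150000 nM in this assay, within a range from 30000 nM to 600000 nM, most probably reported again as a limit only.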

Compound 4, half-maximal inhibitory concentration: > 100000 nM
Compound 4: a limit, no number; the forecaster's own chance of this, stated with the estimate: 80%; the middle value does not contradict the limit.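

Compound 3 and compound 4 both return only a limit, so no step can be read between them: the limit of > 100000 nM in this assay, at which 3 of the 4 values shown sit.

The compounds shown leave open whether fluoro in place of hydroxy on a saturated chain carbon bound to three saturated chain carbons changes this read-out at all.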